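The source may hold more compounds than are shown below. What is called first, only, known or untested is meant among the compounds shown, and "the series" means these compounds.

Among the measured compounds shown here, compound 1, `O=C(/C=C/C(=O)N1C/C(=C\c2ccccc2)C(=O)/C(=C/c2ccccc2)C1)Nc1ccc(Cl)c(Cl)c1`, is one of three compounds measured in a functional assay on Molt4/C8 cells (Homo sapiens) for cytotoxicity (on this read-out lower numbers stand for stronger inhibition and higher numbers for weaker inhibition), where compound 1 gives 1700 nM, the highest of the three numbers. Compound 2, `O=C(/C=C/C(=O)N1C/C(=C\c2ccc([N+](=O)[O-])cc2)C(=O)/C(=C/c2ccc([N+](=O)[O-])cc2)C1)Nc1ccc(Cl)c(Cl)c1`, gives 600 nM in this assay, and compound 3, `CC(=O)c1ccc(NC(=O)/C=C/C(=O)N2C/C(=C\c3ccc([N+](=O)[O-])cc3)C(=O)/C(=C/c3ccc([N+](=O)[O-])cc3)C2)cc1`, gives 390 nM. For the measured compounds named here, the only single-site step measured so far is a 1.5-fold lower number from compound 2 to compound 3 (0.19 log units; within the scatter), which swaps the aromatic group attached to the amide-type nitrogen while the rest of the molecule is kept.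

Compound 4, `O=C(/C=C/C(=O)N1C/C(=C\c2ccccc2)C(=O)/C(=C/c2ccccc2)C1)Nc1ccc(Cl)cc1`, is compound 1 with one change: hydrogen in place of chloro on an aromatic carbon, so that the 3,4-dichlorophenyl group becomes a 4-chlorophenyl group. Going by the values given here, no measured step removes a chloro group, and the one step that touches the amide-side aromatic group stays within the scatter. The expected step is therefore no change at the digits printed from compound 1 to compound 4 (within the scatter), with nothing beyond the usual scatter foreseen. Compound 4 is estimated at 1700 nM, with a range from 600 nM to 4800 nM.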

Compound 4, half-maximal inhibitory concentration: 1800 nM
Compound 4: middle estimate off by 1.1-fold (0.02 log units), on the low side; the measured number falls inside the stated range.
By their numbers in this assay, from the lowest: compounds 3 and 2 (each within the scatter of the next); then compounds 1 and 4 (each within the scatter of the next).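

In this assay, the change from 3,4-dichlorophenyl to 4-chlorophenyl gives a 1.1-fold higher number from compound 1 to compound 4 (0.02 log units; within the scatter) and stays within the scatter. Among the compounds shown here, this is the first measured step that alters a single atom on the amide-side aromatic ring, and the first single-site step on the core of compound 1, which lacks the nitro groups of compound 2 and compound 3. At this position, ortho to a chloro group and meta to a large group, the chloro group can therefore give way to hydrogen with no change beyond the scatter, and no supporting data are available to explain this result.

The compounds shown leave open what the remaining chloro group contributes, and whether a methoxy group or an amine on this ring would give a similar number. They also leave open whether the same change would read alike on the core of compound 2.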